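Amide substituent variation: estimate for compound 3

The source may report more compounds than this note shows. Statements on the series, on what has been measured and on what is new or still open speak of the compounds shown alone.

Measured in an assay on HL-60 cells for agonist activity at vitamin D3 receptor (Homo sapiens), read by microscopy, with a stated time of 96 h; a lower number here means that less compound is needed, a higher number that more compound is needed for the effect:
compound 1 `CCn1c(C(=O)NCC(OC)OC)ccc1C(CC)(CC)c1ccc(OCC(O)C(C)(C)C)c(C)c1`: 150 nM
compound 2 `CCn1c(C(=O)N(CCC#N)CCC#N)ccc1C(CC)(CC)c1ccc(OCC(O)C(C)(C)C)c(C)c1`: 97 nM

Within the data shown here, only two compounds have numbers. Compound 2 carries the smaller of the two, but the gap to compound 1 does not exceed the scatter: a 1.5-fold lower number from compound 1 to compound 2 (0.19 log units; within the scatter). On the numbers shown the two are not separated.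

Compound 3 `CCOc1ccc(NC(=O)c2ccc(C(CC)(CC)c3ccc(OCC(O)C(C)(C)C)c(C)c3)n2CC)cc1` differs from compound 2 only at the carbonyl carbon whose other neighbour is aromatic carbon: a group of 10 heavy atoms (8 carbon, 1 nitrogen, 1 oxygen; one six-membered aromatic ring of carbon only) in place of a group of 9 heavy atoms (6 carbon, 3 nitrogen; no ring), on a carbonyl carbon.

Among the measured compounds shown here, the one measured step that bears on this position, a 1.5-fold lower number from compound 1 to compound 2 (0.19 log units; within the scatter), exchanged two acyclic amide substituents and stayed within the scatter. For the measured compounds named here, the present change brings an aromatic ring into this position, for which no measured step exists, so the range is kept wider. No step beyond the scatter is expected in this assay.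

Compound 3 is therefore estimated at 110 nM, with a range from 40 nM to 350 nM. The expected step is a 1.1-fold higher number from compound 2 to compound 3 (0.05 log units; within the scatter).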

Compound 3, half-maximal effective concentration: 630 nM
Estimate against measurement, compound 3: 5.7-fold (0.76 log units) below; the whole stated range lies below it.
By their numbers in this assay, from the lowest: compounds 2 and 1 (each within the scatter of the next); then compound 3.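

In this assay this position proves sensitive to the amide substituent: (4-ethoxyphenyl)amino on the carbonyl carbon gives a 6.5-fold higher number from compound 2 to compound 3 (0.81 log units; beyond the scatter) in place of the acyclic group of compound 2, and 4-ethoxyphenyl in place of 2,2-dimethoxyethyl on the amide-type nitrogen gives a 4.2-fold higher number from compound 1 to compound 3 (0.62 log units; beyond the scatter) as well. Among these compounds, the two acyclic substituents stayed unseparated, with a 1.5-fold lower number from compound 1 to compound 2 (0.19 log units; within the scatter) as their step, so the aromatic substituent of compound 3 is the first here to stand apart from the others, on the side of the higher number. The amide hydrogen does not set compound 3 apart, as compound 1 carries it too, and no measurement shown explains the shift.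

On these data alone, whether the shift follows the aromatic ring or its ethoxy group remains open. A plain phenyl amide or a benzyl amide would separate these two readings.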